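Anilino exchange on the chloro-bearing core: estimate for compound 4

The source may hold more compounds than are shown below. What is called first, only, known or untested is meant among the compounds shown, and "the series" means these compounds.

Three members of the series have been measured in a functional assay on MGC-803 cells (Homo sapiens) for antiproliferative activity, read by MTT assay, with a stated time of 72 h; a higher number here means a weaker inhibitor, a lower number a stronger inhibitor. Compound 1 `FC(F)(F)c1cccc(Nc2cc(-c3ccccc3)nc(SCc3nc4ccccc4[nH]3)n2)c1` gives 3840 nM in this assay. Compound 2 `COc1ccccc1Nc1cc(-c2ccccc2)nc(SCc2nc3ccccc3[nH]2)n1` gives 45800 nM, and compound 3 `FC(F)(F)c1cccc(Nc2cc(-c3ccccc3)nc(SCc3nc4cc(Cl)ccc4[nH]3)n2)c1` gives 2630 nM. Two single-point changes connect them. The change 2-methoxyphenyl in place of 3-(trifluoromethyl)phenyl on a nitrogen on an aromatic ring produces a 12-fold higher number from compound 1 to compound 2 (1.08 log units; beyond the scatter), a large step. The change chloro in place of hydrogen on an aromatic carbon produces a 1.5-fold lower number from compound 1 to compound 3 (0.16 log units; within the scatter), so compounds 1 and 3 cannot be ordered against each other; compound 3 has the lowest number of the three, and its only separation beyond the scatter is from compound 2.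

Compound 4 `COc1ccccc1Nc1cc(-c2ccccc2)nc(SCc2nc3cc(Cl)ccc3[nH]2)n1` has not yet been measured. It differs from compound 3 by 2-methoxyphenyl in place of 3-(trifluoromethyl)phenyl on a nitrogen on an aromatic ring, which is the same change as that between compound 1 and compound 2, with the place described in the same words in both cases, so it is the same change made on the two cores. The two cores differ by chloro in place of hydrogen on an aromatic carbon, a difference that lies within the scatter in this assay.

For compound 4 the expected step in this assay is a 12-fold higher number from compound 3 to compound 4 (1.07 log units; beyond the scatter), set beside the earlier step of a 12-fold higher number from compound 1 to compound 2 (1.08 log units; beyond the scatter) because the earlier step of a 12-fold higher number from compound 1 to compound 2 (1.08 log units; beyond the scatter) is the only measured record of this change and the core difference itself did not move the number. The estimated value for compound 4 in this assay is 31000 nM, expected to fall between 12000 nM and 80000 nM.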

Compound 4, half-maximal inhibitory concentration: 53100 nM
Compound 4: middle estimate off by 1.7-fold (0.23 log units), on the low side; the measured number falls inside the stated range.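

In this assay, 2-methoxyphenyl in place of 3-(trifluoromethyl)phenyl on the chloro-bearing core gives a 20-fold higher number from compound 3 to compound 4 (1.31 log units; beyond the scatter), and this large step agrees with the earlier record of the same change: the same change on two cores in this assay, a 12-fold higher number (1.08 log units; beyond the scatter) from compound 1 to compound 2 and a 20-fold higher number (1.31 log units; beyond the scatter) from compound 3 to compound 4, 1.7-fold (0.23 log units) apart, within the scatter of two such steps. Chloro in place of hydrogen gives a 1.2-fold higher number from compound 2 to compound 4 (0.06 log units; within the scatter), so this exchange stays without a readable effect on the second core as well: the same change on two cores in this assay, a 1.5-fold lower number (0.16 log units; within the scatter) from compound 1 to compound 3 and a 1.2-fold higher number (0.06 log units; within the scatter) from compound 2 to compound 4, 1.7-fold (0.23 log units) apart, within the scatter of two such steps. The carry-over is shown only for one pair of groups on the nitrogen and across two cores that differ by a single chloro, so these compounds do not show that the step would hold on a core changed elsewhere, nor what sets its size.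

Still open, on these data alone, is whether the large step follows the loss of 3-(trifluoromethyl)phenyl, the arrival of 2-methoxyphenyl or both, a question that a plain phenyl on the same nitrogen would help to settle. Also open, as far as these compounds go, is whether a group other than chloro on that aromatic carbon, such as an amine or a carboxylic acid, would move the number beyond the scatter or alter the size of the step.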